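This account rests on a few compounds, and the source may have more. Where it says the series, first, only, none or still open, it means among the compounds named here.

Compound 1 `Cc1cccc(Cc2nc3cc(O[C@H]4CC[C@@H](C(=O)O)CC4)ccc3n2C)c1` is one of two compounds with a result in an assay on isolated protein for inhibition of Long-chain-fatty-acid--CoA ligase 1 (Mus musculus), read by mass spectrometry, with a stated time of 90 min, in the presence of a further agent that is not named here (on this read-out lower numbers stand for stronger inhibition and higher numbers for weaker inhibition), and in this assay compound 1 gives 30 nM, the only number shown. Compound 2 `Cc1cccc(Cc2nc3ccc(O[C@H]4CC[C@@H](C(=O)O)CC4)cc3n2C)c1` returns in this assay only a limit, as compound 2 gives > 200000 nM. The second value therefore sits at the limit of > 200000 nM in this assay, at which 1 of the 2 values shown sits, and nothing beyond these two values can be said about the pair. Among the measured compounds shown here, compound 1 thus stands as the sole measured number, with the other compound at a limit.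

Compound 3 `Cn1c(Cc2cccnc2)nc2cc(O[C@H]3CC[C@@H](C(=O)O)CC3)ccc21` differs from compound 1 by one change: pyridin-3-yl in place of 3-methylphenyl on a saturated chain carbon bound to an aromatic carbon. For the measured compounds named here, no measured step matches this change, so the expectation rests on compound 1 alone. The author expects a modest loss of strength, with a step from compound 1 to compound 3 of about a 5.0-fold higher number from compound 1 to compound 3 (0.70 log units; beyond the scatter), which lies somewhat beyond the scatter. The estimate for compound 3 in this assay is accordingly 150 nM, with a range from 30 nM to 800 nM.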

Compound 3, half-maximal inhibitory concentration: > 200000 nM
Compound 3 gave a limit, no number; the forecaster's own chance of this, stated with the estimate: 5%; middle value at least 1300-fold (3.12 log units) away from the limit.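

In this assay compound 3 gives > 200000 nM, which is a limit of the assay and not a number. Among the compounds shown here, the change from 3-methylphenyl to pyridin-3-yl on a saturated chain carbon bound to an aromatic carbon gives an at least 6600-fold higher number from compound 1 to compound 3 (3.82 log units; beyond the scatter), far beyond the scatter, and it shows for the first time that the strength of compound 1 depends on the group at this place, with the rest of the structure unchanged. Only compound 1 keeps a number in this pair, so the step has a lower bound but no measured size: the limit of > 200000 nM in this assay, at which 2 of the 3 values shown sit.

For the compounds shown here, the single change brings in a ring nitrogen and removes the methyl at once, so it remains open which of the two carries the loss, a question that a plain phenyl or a methyl-bearing pyridin-3-yl at this place would address. Going by these compounds, it is also open whether any ring nitrogen is poorly accepted here, as with pyridin-2-yl or pyridin-4-yl, or whether another group at the same ring place, such as chloro in 3-chlorophenyl, could stand in for the methyl.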